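Hexyl for chloro on the shared core

The compounds below may be only part of what the source reports. "The series", "measured", "known", "first", "only" and "open" are said of these compounds alone.

Working notes on the series. Going by the values given here, compound 1 `O=C(O)CCCC(=O)n1ccc2ccc(Cl)cc21` is measured in a functional assay on isolated protein for antagonist activity at Oxoeicosanoid receptor 1 (Homo sapiens), read by fluorescence and calcium flux, with stated times of 2 min and 1 min (on this read-out higher numbers stand for weaker inhibition and lower numbers for stronger inhibition), and gives 400 nM, the lowest of the two numbers so far. Compound 2 `CCCCCCc1ccc2c(ccn2C(=O)CCCC(=O)O)c1` carries a hexyl group elsewhere on the same core; in this assay compound 2 gives 17700 nM, a higher number than compound 1 and beyond the scatter. Compound 3 `CCCCCCc1ccc2ccn(C(=O)CCCC(=O)O)c2c1` is not yet measured. It differs from compound 1 in one place: hexyl in place of chloro on an aromatic carbon. Among the compounds with values here, no step of this kind is yet measured, so the size of the step rests on the two values alone. Because compound 2 gives 17700 nM with hexyl on the core, the step from compound 1 is expected to go toward weaker inhibition, more than the scatter. Compound 3 is estimated at 3000 nM, within 600 nM to 15000 nM, meaning an expected step of a 7.5-fold higher number from compound 1 to compound 3 (0.88 log units; beyond the scatter).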

Compound 3, half-maximal inhibitory concentration: 18000 nM
For compound 3 the middle estimate is 6.0-fold (0.78 log units) below the measured one; measured number outside the range, above it.
By their numbers in this assay, from the lowest: compound 1; then compounds 2 and 3 (each within the scatter of the next).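

In this assay, going by these compounds alone, the change from chloro to hexyl on this aromatic carbon gives the first direct one-place reading at this position: a 45-fold higher number from compound 1 to compound 3 (1.65 log units; beyond the scatter), a large move toward weaker inhibition. With hexyl at this carbon, compound 3 gives 18000 nM, and with hexyl elsewhere on the shared core, compound 2 gives 17700 nM; these two values lie within the scatter of each other, so the compounds shown do not separate the two hexyl placements. No measurement at hand explains the size of this step.

Still open, as far as these compounds go, is whether a shorter chain such as ethyl or butyl at this aromatic carbon would give a value nearer that of compound 1 or that of compound 3. From the compounds shown here alone, it is also open how a bromo or methoxy group would compare with chloro at the same carbon.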